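Benzyl ether substituent changes on the shared core

The source may hold more compounds than are shown below. What is called first, only, known or untested is meant among the compounds shown, and "the series" means these compounds.

Measured compounds:
compound 1 `O=C(Nc1cccnc1)c1ccccc1OCc1ccccc1` — 3200 nM
compound 2 `O=C(Nc1cccnc1)c1ccccc1OCc1ccccc1F` — 3500 nM
compound 3 `O=C(Nc1cccnc1)c1ccccc1OCc1ccccc1C(F)(F)F` — 2100 nM

In an assay on lysate for inhibition of phosphatidylcholine:ceramide cholinephosphotransferase 2 (Homo sapiens), read by HPLC, with stated times of 30 min and 2 h (a higher number here means a weaker inhibitor, a lower number a stronger inhibitor), compound 3 gives the lowest of the three numbers, but its neighbours sit close: the step of a 1.5-fold lower number from compound 1 to compound 3 (0.18 log units; within the scatter) and the step of a 1.7-fold lower number from compound 2 to compound 3 (0.22 log units; within the scatter) are both within the scatter, so compound 3 cannot be called the strongest inhibitor on these data. The step of a 1.1-fold higher number from compound 1 to compound 2 (0.04 log units; within the scatter) is likewise within the scatter. The three measured compounds thus describe a flat series in this assay.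

Compound 4 `N#Cc1ccccc1COc1ccccc1C(=O)Nc1cccnc1` is the next entry. Its change from compound 3 is cyano in place of trifluoromethyl on an aromatic carbon. The measured steps that bear on this position are those just named, all of them within the scatter, and none involves a cyano group, so no step beyond the scatter is expected in this assay in either direction. Compound 4 is therefore estimated at 2500 nM, with a range from 1000 nM to 6000 nM. From compound 3 this estimate means a step of a 1.2-fold higher number from compound 3 to compound 4 (0.08 log units; within the scatter), expected to stay within the scatter.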

Compound 4, half-maximal inhibitory concentration: 31800 nM
The estimate for compound 4 lay 13-fold (1.10 log units) below the measured number; measured number outside the range, above it.
By their numbers in this assay, from the lowest: compounds 3, 1 and 2 (each within the scatter of the next); then compound 4.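

In this assay this position turns out not to be indifferent to the group it carries: cyano in place of trifluoromethyl gives a 15-fold higher number from compound 3 to compound 4 (1.18 log units; beyond the scatter), cyano in place of fluoro gives a 9.1-fold higher number from compound 2 to compound 4 (0.96 log units; beyond the scatter), and cyano in place of hydrogen gives a 9.9-fold higher number from compound 1 to compound 4 (1.00 log units; beyond the scatter). Hydrogen, fluoro and trifluoromethyl remain within the scatter of one another, so the series is flat only across those three groups, and compound 4 is the weakest inhibitor of the four, with its steps to all the others beyond the scatter. No measurement shown here accounts for the difference seen with cyano.

As far as these compounds go, whether this higher number is particular to cyano, or also comes with an amine, a carboxylic acid or a methoxy group at this position, remains open. Also open, from the compounds shown here alone, is whether cyano elsewhere on this ring gives a step of similar size.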